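The compounds below may be only part of what the source reports. "The series", "measured", "known", "first", "only" and "open" are said of these compounds alone.

Measured in an ADME assay on microsomes from liver (Mus musculus, strain CD-1) for metabolic stability, read by LC-MS, tested at 2 uM; on this read-out lower numbers stand for a shorter-lived compound and higher numbers for a longer-lived compound:
- compound 1 `Cn1ccc2ccc(-c3cc(Nc4cnccc4C(=O)NCc4cncnc4)cc4nccnc34)cc21`: 0.4 h
- compound 2 `CC(=O)N1CCC(NC(=O)c2ccncc2Nc2cc(-c3ccc4ccn(C)c4c3)c3nccnc3c2)CC1`: 0.117 h
- compound 3 `CC(=O)N1CCCC(NC(=O)c2ccncc2Nc2cc(-c3ccc4ccn(C)c4c3)c3nccnc3c2)C1`: 0.4 h

Compound 3 stands level with compound 1, as no change at the digits printed from compound 1 to compound 3 (within the scatter) shows, and clear of compound 2, as a 3.4-fold higher number from compound 2 to compound 3 (0.53 log units; beyond the scatter) shows. The next change leads to compound 4 `CC(=O)N1CC(NC(=O)c2ccncc2Nc2cc(-c3ccc4ccn(C)c4c3)c3nccnc3c2)C1`: 1-acetylazetidin-3-yl in place of 1-acetylpiperidin-3-yl on an amide-type nitrogen. In words, 1-acetylazetidin-3-yl comes in place of 1-acetylpiperidin-3-yl on an amide-type nitrogen, and the rest of the molecule stays as it is.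

Among the compounds with values here, three measured steps bear on this change, all at the same amide-type nitrogen. The closest is a 3.4-fold higher number from compound 2 to compound 3 (0.53 log units; beyond the scatter), since it also swaps one acetylated ring substituent for another. The replacement of the (pyrimidin-5-yl)methyl group gives a 3.4-fold lower number from compound 1 to compound 2 (0.53 log units; beyond the scatter) in one case and no change at the digits printed from compound 1 to compound 3 (within the scatter) in the other. Changes at this nitrogen have therefore ranged from nothing visible to a modest step. Within the data shown here, no compound with a four-membered ring has been measured, so the data give no direction for this change. No step beyond the scatter is expected, and the estimated step is no change at the digits printed from compound 3 to compound 4 (within the scatter). The range is kept wide enough to admit a modest step either way. For compound 4 the estimated half-life is 0.4 h, with an expected range of 0.15 h to 1 h.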

Compound 4, half-life: 0.817 h
Compound 4: middle estimate off by 2.0-fold (0.31 log units), on the low side; the range from low to high includes it.
By their numbers in this assay, from the lowest: compound 2; then compounds 1 and 3 (each within the scatter of the next); then compound 4.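

In this assay, within the data shown here, 1-acetylazetidin-3-yl is the first group at this amide-type nitrogen to lift the number above the level shared by compound 1 and compound 3 (in steps of a 2.0-fold higher number from compound 3 to compound 4 (0.31 log units; beyond the scatter) and a 2.0-fold higher number from compound 1 to compound 4 (0.31 log units; beyond the scatter)), so that level is not a ceiling for this position. The spread among the acetylated rings also widens (to a 7.0-fold higher number from compound 2 to compound 4 (0.84 log units; beyond the scatter)), and compound 4 now stands clear of all three earlier compounds, with each step to it printed as beyond the scatter. No measurement at hand accounts for this rise.

From the compounds shown here alone, it remains open whether the higher number goes with the four-membered ring itself or with the acetyl group on it, and a methanesulfonyl group or a free amine on the azetidine ring nitrogen would tell these apart. Also open, going by these compounds, is whether a 1-acetylpyrrolidin-3-yl group, with its five-membered ring, would fall between compound 3 and compound 4 or would behave differently from both.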